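Seeking a number for compound 4

This account rests on a few compounds, and the source may have more. Where it says the series, first, only, none or still open, it means among the compounds named here.

Values in a functional assay on A549 cells (Homo sapiens) for antiproliferative activity, read by MTT assay, with a stated time of 72 h (on this read-out higher numbers stand for weaker inhibition and lower numbers for stronger inhibition), are as follows:
compound 1 `O=C(N/N=C/c1ccc(F)cc1)Nc1ccc(Oc2ccnc3[nH]ccc23)c(F)c1` gives 680 nM
compound 2 `O=C(N/N=C/c1cccc([N+](=O)[O-])c1)Nc1ccc(Oc2ccnc3[nH]ccc23)c(F)c1` gives 3640 nM
compound 3 `O=C(N/N=C/c1cccc(Cl)c1Cl)Nc1ccc(Oc2ccnc3[nH]ccc23)c(F)c1` gives "not active" (no number reported)

Compound 3 has no number in this assay and was reported only as not active. Compound 4 `O=C(N/N=C/c1ccc(F)cc1Cl)Nc1ccc(Oc2ccnc3[nH]ccc23)c(F)c1` differs from it in one group (2-chloro-4-fluorophenyl in place of 2,3-dichlorophenyl on a carbon with a double bond to nitrogen), with 2-chloro-4-fluorophenyl in place of 2,3-dichlorophenyl on a carbon with a double bond to nitrogen. Among the compounds with values here, the only measured step at that place (a 5.4-fold higher number from compound 1 to compound 2 (0.73 log units; beyond the scatter)) was modest but beyond the scatter, and it involved different groups, so it bears only loosely. No step size can be worked out from compound 3, but the expected direction is toward stronger inhibition, within reach of compound 1 (680 nM), which carries 4-fluorophenyl. For compound 4 the expected value is 1500 nM (estimated range 350 nM to 7000 nM).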

Compound 4, half-maximal inhibitory concentration: 10 nM
The estimate for compound 4 lay 150-fold (2.18 log units) above the measured number; measured number outside the range, below it.
By their numbers in this assay, from the lowest: compound 4; then compound 1; then compound 2.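

In this assay, chloro in place of hydrogen on an aromatic carbon brings a 68-fold lower number from compound 1 to compound 4 (1.83 log units; beyond the scatter) and shows that one added atom on this ring can matter greatly. The substituents here span a wide range, with a 360-fold lower number from compound 2 to compound 4 (2.56 log units; beyond the scatter) while compound 3, which also carries chloro, was reported as not active, so chloro alone does not secure activity. Nothing available explains this gain. On these data alone, whether bromo or methyl could replace this chloro remains open. So does the activity of a plain 2-chlorophenyl group without the fluorine.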